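The source may report more compounds than this note shows. Statements on the series, on what has been measured and on what is new or still open speak of the compounds shown alone.

Three chalcones that share a core, built from a methoxy-bearing aromatic ring on a double-bonded chain and a fluorophenyl-substituted aryl ketone, have been tested in a functional assay on CNE-2 cells (Homo sapiens) for cytotoxicity, read by sulforhodamine B assay, with a stated time of 48 h; a lower number here means a stronger inhibitor, a higher number a weaker inhibitor. Compound 2 `COc1ccccc1/C=C/C(=O)c1cccc(-c2cccc(F)c2)c1` gives 10400 nM in this assay. Compound 1 `COc1cccc(/C=C/C(=O)c2cccc(-c3cccc(F)c3)c2)c1OC` carries an added methoxy group, the change (methoxy in place of hydrogen on an aromatic carbon), and gives 10000 nM in this assay; the step of a 1.0-fold lower number from compound 2 to compound 1 (0.02 log units; within the scatter) lies within the scatter. Compound 3 `COc1ccc(/C=C/C(=O)c2cccc(-c3cccc(F)c3)c2)cc1` differs from compound 2 by 4-methoxyphenyl in place of 2-methoxyphenyl on a double-bonded chain carbon bound to a double-bonded chain carbon, and in this assay compound 3 gives 740 nM; the step of a 14-fold lower number from compound 2 to compound 3 (1.15 log units; beyond the scatter) is the large one in this set, and compound 3 shows the lowest number of the three.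

Compound 4 `COc1ccc(/C=C/C(=O)c2cccc(-c3cccc(F)c3)c2)cc1OC` has not yet been measured in this assay. It differs from compound 3 by methoxy in place of hydrogen on an aromatic carbon, the same change as from compound 2 to compound 1, set on a different core whose difference is given by 4-methoxyphenyl in place of 2-methoxyphenyl on a double-bonded chain carbon bound to a double-bonded chain carbon. Going by the values given here, the one measured instance of this change, a 1.0-fold lower number from compound 2 to compound 1 (0.02 log units; within the scatter), left the number where it was. The account therefore expects a step of a 1.2-fold higher number from compound 3 to compound 4 (0.09 log units; within the scatter) from compound 3 to compound 4, resting on the step of a 1.0-fold lower number from compound 2 to compound 1 (0.02 log units; within the scatter), with the caveat that the core now differs. Compound 4 is estimated to give 900 nM in this assay, with a range of 300 nM to 2700 nM.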

Compound 4, half-maximal inhibitory concentration: 770 nM
Compound 4: the middle estimate sits 1.2-fold (0.07 log units) above what was measured; the measured number falls inside the stated range.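

In this assay, adding a methoxy group to the core of compound 3 gives a step that lies within the scatter, a 1.0-fold higher number from compound 3 to compound 4 (0.02 log units; within the scatter), so compound 4 stays in the same range as compound 3 and the lower number seen with the 4-methoxyphenyl core is kept. Set beside the earlier instance, the change reads the same on the two cores, even though those cores themselves stand far apart in this assay: the same change on two cores in this assay, a 1.0-fold lower number (0.02 log units; within the scatter) from compound 2 to compound 1 and a 1.0-fold higher number (0.02 log units; within the scatter) from compound 3 to compound 4, 1.1-fold (0.03 log units) apart, within the scatter of two such steps This shows only that, in these two pairs and in this one assay, the added methoxy group brought no step beyond the scatter; two pairs do not establish a rule for the series, and they do not show that the change would behave alike on any other core or at any other place on the ring.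

The compounds shown leave open whether a hydroxyl, an amine or a longer chain such as ethoxy, set in place of this added methoxy group, would also stay within the scatter. Every compound shown also keeps the fluorophenyl group on the aryl ketone, so it remains open whether the same reading would hold with a carboxylic acid or a nitrile on that part of the molecule.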